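Swapping Methyl for Chloro on the Benzyl Arm

The source may hold more compounds than are shown below. What is called first, only, known or untested is meant among the compounds shown, and "the series" means these compounds.

Compound 1 `CC(C)CSc1n[nH]c(-n2[se]c3ccccc3c2=O)n1`: in a functional assay on SMMC-7721 cells (Homo sapiens) for antiproliferative activity, read by CCK-8 assay, with a stated time of 48 h (a lower number here means a stronger inhibitor, a higher number a weaker inhibitor), compound 1 gives 35000 nM.
Compound 2 `CCCCCCSc1n[nH]c(-n2[se]c3ccccc3c2=O)n1`: compound 2 gives 22400 nM.
Compound 3 `Cc1ccc(CSc2n[nH]c(-n3[se]c4ccccc4c3=O)n2)cc1`: compound 3 gives > 50000 nM, which is a limit of the assay and not a number.

Among the three measured compounds, compound 3 is the only one that sits at the limit (the limit of > 50000 nM in this assay, at which 1 of the 3 values shown sits). Against compound 1 the step is an at least 1.4-fold higher number from compound 1 to compound 3 (0.15 log units; that floor lies within the scatter); against compound 2 it is an at least 2.2-fold higher number from compound 2 to compound 3 (0.34 log units; beyond the scatter). Between the two shorter chains, a 1.6-fold lower number from compound 1 to compound 2 (0.19 log units; within the scatter).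

Compound 4 `O=c1c2ccccc2[se]n1-c1nc(SCc2ccc(Cl)cc2)n[nH]1` differs from compound 3 by chloro in place of methyl on an aromatic carbon. Going by the values given here, none of the measured steps bears directly on this change: each of them trades the whole group bound to the sulfur, and none alters a group on the aromatic ring. Among the compounds with values here, the measured steps show only that compound 3 is weaker than compound 2 and no stronger than compound 1. Within the data shown here, with no precedent for a change on the ring, the expectation for a step that the limit leaves unreadable from compound 3 to compound 4 is no step beyond the scatter, so compound 4 is expected to remain near the limit. Compound 4 is therefore estimated at 60000 nM, with a range from 25000 nM to 150000 nM.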

Compound 4, half-maximal inhibitory concentration: 33900 nM
For compound 4 the middle estimate is 1.8-fold (0.25 log units) above the measured one; the measured number falls inside the stated range.
By their numbers in this assay, from the lowest: compounds 2, 4 and 1 (each within the scatter of the next). At a limit, above all of these: compound 3.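

Compound 3 is the one compound at a limit, which is not a number: the limit of > 50000 nM in this assay, at which 1 of the 4 values shown sits.

Replacing its methyl with chloro on the aromatic carbon brings the series back to a measurable reading in this assay, and the step is an at least 1.4-fold lower number from compound 3 to compound 4 (0.16 log units; that floor lies within the scatter), so only a floor is known and even that floor does not clear the usual scatter. The result still adds something new, since the 4-chlorobenzyl arm of compound 4 reads alongside both saturated chains, with a 1.5-fold higher number from compound 2 to compound 4 (0.18 log units; within the scatter) and a 1.0-fold lower number from compound 1 to compound 4 (0.01 log units; within the scatter), whereas the step from compound 2 to the 4-methylbenzyl arm of compound 3 was beyond the scatter. A benzyl arm on the sulfur therefore does not by itself put a compound at the limit: compound 4 carries one and gives a number, while compound 3 carries one and stays at the limit.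

On these data alone, the full size of the step from methyl to chloro remains unknown, as compound 3 has no number to set against compound 4. As far as these compounds go, only these two groups appear on this aromatic carbon, so it stays open whether a methoxy, a nitrile or a carboxylic acid there would give a clearly lower number.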